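A few compounds are considered here, and "the series" means these few. Any claim that something is new, unique, unknown or untested is made for them only; others in the source may bear on it.

Three compounds share one core, a phthalimide-like ring attached to a thiazole that carries a phenyl group. Compound 1 is `O=C1c2ccccc2C(=O)N1c1nc(-c2ccccc2)cs1`; in a functional assay on PC-3 cells (Homo sapiens) for antiproliferative activity, read by MTT assay, with a stated time of 48 h (a higher number here means a weaker inhibitor, a lower number a stronger inhibitor), compound 1 gives 43900 nM. Compound 2 is `O=C1c2ccccc2C(=O)N1c1nc(-c2ccc([N+](=O)[O-])cc2)cs1`, and in this assay compound 2 gives 41800 nM. Compound 3 is `O=C1c2ccc(F)cc2C(=O)N1c1nc(-c2ccccc2)cs1`, and in this assay compound 3 gives 40200 nM. All three numbers lie within the scatter of one another, so none of the three can be separated from the others; compound 3 is closest to compound 2 and furthest from compound 1, yet both gaps are within the scatter.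

Two steps have been measured. The change of nitro in place of hydrogen on an aromatic carbon gave a 1.1-fold lower number from compound 1 to compound 2 (0.02 log units; within the scatter), and the change of fluoro in place of hydrogen on an aromatic carbon gave a 1.1-fold lower number from compound 1 to compound 3 (0.04 log units; within the scatter). Neither moved the number beyond the scatter.

Compound 4 is `N#Cc1ccc(-c2csc(N3C(=O)c4ccc(F)cc4C3=O)n2)cc1`. It differs from compound 3 by cyano in place of hydrogen on an aromatic carbon, at a place on an aromatic carbon of a six-membered aromatic ring of carbon only, para to a large group, so that the phenyl becomes 4-cyanophenyl. The step from compound 1 to compound 2 bears most directly on it, since it also placed a substituent on that phenyl ring, and it stayed within the scatter. No step beyond the scatter is therefore expected in this assay for compound 4, and the estimated step is a 1.0-fold lower number from compound 3 to compound 4 (0.00 log units; within the scatter). Compound 4 is expected to give 40000 nM, with a range from 20000 nM to 80000 nM.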

Compound 4, half-maximal inhibitory concentration: 43100 nM
Estimate against measurement, compound 4: 1.1-fold (0.03 log units) below, within the range that was stated.
By their numbers in this assay, from the lowest: compounds 3, 2, 4 and 1 (each within the scatter of the next).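

In this assay, cyano in place of hydrogen on an aromatic carbon, para to a large group, gave a 1.1-fold higher number from compound 3 to compound 4 (0.03 log units; within the scatter). This adds a second substituent at this place on the phenyl ring, after the nitro of a 1.1-fold lower number from compound 1 to compound 2 (0.02 log units; within the scatter), and it does so on the fluoro-bearing core of compound 3 rather than on the unsubstituted core of compound 1, so the fluoro and the cyano now stand together in one compound without the number leaving the scatter of its parent. The data shown therefore give two single changes at this place, on two different cores, and neither can be told apart from no change at all, while nothing measured here speaks to why that is so.

All four compounds remain within the scatter of one another, so the compounds shown do not reveal any change on the phenyl ring that moves the number in this assay at all. From the compounds shown here alone, whether an amine, a carboxylic acid or a longer chain such as butyl at this same place would take the number beyond the scatter, in either direction, stays open.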